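The source may hold more compounds than are shown below. What is called first, only, known or untested is meant among the compounds shown, and "the series" means these compounds.

In a functional assay on KB cells (Homo sapiens) for cytotoxicity, read by resazurin assay, with a stated time of 3 days (a lower number here means a stronger inhibitor, a higher number a weaker inhibitor), compound 1 `CCCC(C)C(=O)NCC(C)(C)CC1=C(O)C(=O)c2ccccc2C1=O` gives 47100 nM, compound 2 `CCCCCC(=O)NCC(C)(C)CC1=C(O)C(=O)c2ccccc2C1=O` gives 40200 nM, and compound 3 `CCCCCC(=O)OCC(C)(C)CC1=C(O)C(=O)c2ccccc2C1=O` gives 41000 nM. Compound 3 therefore stands level with the other two, since all three numbers lie within the scatter of one another. Compound 4 `CCCCCCCCCC(=O)OCC(C)(C)CC1=C(O)C(=O)c2ccccc2C1=O` keeps the ester of compound 3 but carries a longer chain, and the change is butyl in place of hydrogen on a saturated chain carbon, five bonds along the chain from a carbonyl carbon. For the measured compounds named here, no measured step tests such a lengthening, so the evidence is indirect. Rearranging the chain, pentyl in place of 1-methylbutyl, gave a 1.2-fold lower number from compound 1 to compound 2 (0.07 log units; within the scatter). Replacing the amide link with the ester link gave a 1.0-fold higher number from compound 2 to compound 3 (0.01 log units; within the scatter). The combined change gave a 1.1-fold lower number from compound 1 to compound 3 (0.06 log units; within the scatter). These edits left the number unmoved, but none of them added carbon to the chain, so a wide range is warranted. No shift beyond the scatter is expected in this assay, and the estimated change is a 1.2-fold lower number from compound 3 to compound 4 (0.07 log units; within the scatter). For compound 4 the expected value is 35000 nM, with an estimated range of 12000 nM to 70000 nM.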

Compound 4, half-maximal inhibitory concentration: 55500 nM
The estimate for compound 4 lay 1.6-fold (0.20 log units) below the measured number, and the stated range covers the measured number.
By their numbers in this assay, from the lowest: compounds 2, 3, 1 and 4 (each within the scatter of the next).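

For the compounds shown here, this is the first measured step that adds carbon to the chain: butyl in place of hydrogen on a saturated chain carbon, five bonds along the chain from a carbonyl carbon, gives a 1.4-fold higher number from compound 3 to compound 4 (0.13 log units; within the scatter) in this assay. The earlier steps shown here only rearranged the chain or swapped the amide link for the ester link, whereas this one shows that the chain of the ester can carry these extra carbons with no shift beyond the scatter. No measurement shown here accounts for this level result.

The compounds shown leave open whether a still longer chain, or a chain ending in an amine or a carboxylic acid, would move the number beyond the scatter. They also leave open whether adding butyl to the amide of compound 2 would likewise cause no such shift.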